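Swapping the Dimethylpiperazine Arm for a Piperidine Ether

The source may hold more compounds than are shown below. What is called first, only, known or untested is meant among the compounds shown, and "the series" means these compounds.

Compound 1 `Cc1cc(Cl)cc(-c2ccnc3cc(CN4C(=O)CCC4=O)sc23)c1O[C@H]1C[C@H](N)C1`: 3.4 nM
Compound 2 `Cc1cc(Cl)cc(-c2ccnc3cc(CN4C(=O)CCC4=O)sc23)c1O[C@H]1CCCNC1`: 4.6 nM
Compound 3 `Cc1cc(Cl)cc(-c2ccnc3cc(CN4C(=O)CCC4=O)sc23)c1CN1[C@@H](C)CNC[C@@H]1C`: 0.32 nM

In an assay on isolated protein for inhibition of ubiquitin carboxyl-terminal hydrolase 7 (Homo sapiens), read by fluorescence, with stated times of 30 min and 1 h (on this read-out lower numbers stand for stronger inhibition and higher numbers for weaker inhibition), compound 3 gives 0.32 nM, the lowest of the three numbers, and both an 11-fold lower number from compound 1 to compound 3 (1.03 log units; beyond the scatter) and a 14-fold lower number from compound 2 to compound 3 (1.16 log units; beyond the scatter) lie beyond the scatter. Compound 4 `Cc1cc(Cl)cc(-c2ccnc3cc(CN4C(=O)CCC4=O)sc23)c1OC1CCNCC1` differs from compound 3 in one place: (piperidin-4-yl)oxy in place of (2,6-dimethylpiperazin-1-yl)methyl on an aromatic carbon. That brings compound 4 close to compounds 1 and 2, which also carry an oxygen-linked ring with a single nitrogen at that carbon, and a 1.4-fold higher number from compound 1 to compound 2 (0.13 log units; within the scatter) shows those two within the scatter of each other. The two large steps toward compound 3 are the ones that bear here, now run backwards. For compound 4 a large step toward a higher number is therefore expected, a 13-fold higher number from compound 3 to compound 4 (1.10 log units; beyond the scatter). Compound 4 is estimated at 4 nM, between 1.5 nM and 12 nM.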

Compound 4, half-maximal inhibitory concentration: 8 nM
Compound 4: middle estimate off by 2.0-fold (0.30 log units), on the low side; the measured number falls inside the stated range.
By their numbers in this assay, from the lowest: compound 3; then compounds 1, 2 and 4 (each within the scatter of the next, the first and the last beyond it).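

In this assay the piperidin-4-yl ether sits with the other oxygen-linked rings, not with compound 3: a 25-fold higher number from compound 3 to compound 4 (1.40 log units; beyond the scatter) is large, while a 1.7-fold higher number from compound 2 to compound 4 (0.24 log units; within the scatter) stays within the scatter, so shifting the ring's attachment from piperidin-3-yl to piperidin-4-yl changes nothing readable. Against the 3-aminocyclobutyl ether, a 2.4-fold higher number from compound 1 to compound 4 (0.37 log units; beyond the scatter) is a modest gap. No measurement here explains why the (2,6-dimethylpiperazin-1-yl)methyl arm stands apart. Open, from the compounds shown here alone, is whether its advantage follows the two methyl groups, the second ring nitrogen or the carbon link; piperazin-1-ylmethyl and piperidin-4-ylmethyl groups would help separate these.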